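Chloro to methyl exchange under a cytotoxicity ceiling

The compounds below may be only part of what the source reports. "The series", "measured", "known", "first", "only" and "open" are said of these compounds alone.

Three compounds were examined in an ADME assay on J774.A1 cells (Mus musculus) for cytotoxicity, read by MTT assay, with a stated time of 72 h; on this read-out lower numbers stand for an effect already at smaller amounts and higher numbers for an effect only at larger amounts of compound. Compound 1 `CC(C)Nc1nc(NCc2ccco2)c2cccc(Cl)c2n1` reaches only a limit of the assay, > 33000 nM. Compound 2 `CC(C)Nc1nc(NCc2ccco2)c2ccc(Cl)cc2n1` likewise gives a limit, > 100000 nM. The difference between the cores of compound 1 and compound 2 is not broken down here. Compound 3 `Cc1cccc2c(NCc3ccco3)nc(NC(C)C)nc12` also gives a limit, > 33000 nM. Compound 3 arises from compound 1 by methyl in place of chloro on an aromatic carbon, and the measured step is a step that the two limits leave unreadable from compound 1 to compound 3. Compound 4 `Cc1ccc2c(NCc3ccco3)nc(NC(C)C)nc2c1` has not yet been measured in this assay. It arises from compound 2 by the same kind of change, (methyl in place of chloro on an aromatic carbon), the place differing in that it is meta to a fused ring and para to a fused ring rather than ortho to a fused ring and meta to a fused ring. Because the limit of > 33000 nM in this assay, at which 2 of the 3 values shown sit, and the limit of > 100000 nM in this assay, at which 1 of the 3 values shown sits, together cover every value seen, compound 4 is expected to sit at a limit as well. The estimated step is a number no higher from compound 2 to compound 4 (the limit leaves the size open). Compound 4 is expected at 100000 nM, with a range from 33000 nM to 300000 nM.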

Compound 4, half-maximal effective concentration: > 33000 nM
Compound 4: only a limit was reported (the forecaster's own chance of this, stated with the estimate: 85%); the middle value lies beyond the limit too.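

Compound 2 and compound 4 each give only a limit in this assay, and no step can be read between them. The compounds shown leave open at what concentration any of the four would reach a half-maximal effect, and whether methyl in place of chloro on an aromatic carbon changes the read-out at all.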